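The compounds below may be only part of what the source reports. "The series", "measured", "known", "first", "only" and "open" are said of these compounds alone.

Compound 1: `CCCCCCCCNC(=O)[C@@H](NC(=O)c1ccccc1)[C@@H](C)O`; in a functional assay on HepG2 cells (Homo sapiens) for cytotoxicity, read by MTT assay, with a stated time of 48 h (a higher number here means a weaker inhibitor, a lower number a stronger inhibitor), compound 1 gives 136000 nM.
Compound 2: `CCCCCCCCNC(=O)[C@@H](NC(=O)c1nccc2ccccc12)[C@@H](C)O`; in this assay compound 2 gives 88200 nM.
Compound 3: `CCCCCCCCCCCCCCCCCCNC(=O)[C@@H](NC(=O)c1ccccc1)[C@@H](C)O`; in this assay compound 3 gives only > 400000 nM, which is a limit of the assay and not a number.

Compound 3 therefore stands at the weak end of what has been measured, and only a limit is known for it. Among the measured compounds shown here, the one measured step that involves compound 3 is an at least 2.9-fold higher number from compound 1 to compound 3 (0.46 log units; beyond the scatter), where the reading reached the limit (the limit of > 400000 nM in this assay, at which 1 of the 3 values shown sits).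

Compound 4, `CCCCCCCCCCCCCCCCCCNC(=O)[C@@H](NC(=O)c1nccc2ccccc12)[C@@H](C)O`, is reached from compound 3 by one change: isoquinolin-1-yl in place of phenyl on a carbonyl carbon. The same exchange separates compound 1 from compound 2; compound 1 gives 136000 nM and compound 2 gives 88200 nM, two values that lie within the usual scatter of each other, so no change beyond the scatter is shown for that exchange. For the measured compounds named here, no measured step connects compound 3 to compound 4 directly.

The step from compound 3 to compound 4 is therefore expected to be small or none beyond the scatter, a step that the limit leaves unreadable from compound 3 to compound 4, and compound 4 is expected most likely to remain at the limit of the assay. The estimate for compound 4 in this assay is 450000 nM, with a range from 150000 nM to 1300000 nM.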

Compound 4, half-maximal inhibitory concentration: 96900 nM
Compound 4: middle estimate off by 4.6-fold (0.67 log units), on the high side, outside the stated range (below it).
By their numbers in this assay, from the lowest: compounds 2, 4 and 1 (each within the scatter of the next). At a limit, above all of these: compound 3.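

In this assay, isoquinolin-1-yl in place of phenyl on the carbonyl carbon gives an at least 4.1-fold lower number from compound 3 to compound 4 (0.61 log units; beyond the scatter), whereas the same exchange between compound 1 and compound 2 showed nothing beyond the scatter, so on the long-chain core this exchange does register. The added decyl, which moved the number beyond the scatter when phenyl was present, now gives a 1.1-fold higher number from compound 2 to compound 4 (0.04 log units; within the scatter), so with isoquinolin-1-yl in place, lengthening the chain shows no change beyond the scatter. From the compounds shown here alone, compound 3 gives > 400000 nM, which is a limit of the assay and not a number, so the true size of the exchange on its core remains unknown.

Going by these compounds, the same limit means that the two effects of the added decyl cannot be compared exactly: the same change on two cores in this assay, an at least 2.9-fold higher number (0.46 log units; beyond the scatter) from compound 1 to compound 3 and a 1.1-fold higher number (0.04 log units; within the scatter) from compound 2 to compound 4; the limit leaves it open whether they differ Also open is how a dodecyl chain, longer than that of compound 1 and shorter than that of compound 3, would read with phenyl and with isoquinolin-1-yl.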